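Amide in place of acid on an octyl-bearing core

The source may hold more compounds than are shown below. What is called first, only, known or untested is meant among the compounds shown, and "the series" means these compounds.

Measured so far:
compound 1, `C=C1C[C@@H]1CC(=O)O`, 60000 nM
compound 2, `C=C1C[C@@H]1CC(N)=O`, 30000 nM
compound 3, `C=C1[C@@H](CC(=O)O)[C@H]1CCCCCCCC`, 5000 nM

In a functional assay (Hepatocyte) for inhibition, with Rattus norvegicus as the target (on this read-out lower numbers stand for stronger inhibition and higher numbers for weaker inhibition), compound 1 and compound 2 differ by one change only, (amino in place of hydroxy on a carbonyl carbon), and the step is a 2.0-fold lower number from compound 1 to compound 2 (0.30 log units; within the scatter). Compound 3 carries a different core; the difference between the two cores is not broken down here, but in this assay compound 3 gives the lowest number of the three, beyond the scatter from both compound 1 and compound 2.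

Compound 4, `C=C1[C@@H](CC(N)=O)[C@H]1CCCCCCCC`, is not yet measured. It differs from compound 3 by amino in place of hydroxy on a carbonyl carbon, the same change as that from compound 1 to compound 2, at a place described in the same words. Compound 4 is therefore expected to land in this assay at 3000 nM, within roughly 1000 nM to 9000 nM. This estimate rests on the earlier step of a 2.0-fold lower number from compound 1 to compound 2 (0.30 log units; within the scatter) and means an expected step of a 1.7-fold lower number from compound 3 to compound 4 (0.22 log units; within the scatter).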

Compound 4, half-maximal inhibitory concentration: 8000 nM
Compound 4: the middle estimate sits 2.7-fold (0.43 log units) below what was measured; low and high end bracket the measured number.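

On the core of compound 3, amino in place of hydroxy on a carbonyl carbon gives a 1.6-fold higher number from compound 3 to compound 4 (0.20 log units; within the scatter) in this assay, so this pair alone does not separate the acid from the amide. Taken one at a time, both steps lie within the scatter, but set side by side they do not match: the same change on two cores in this assay, a 2.0-fold lower number (0.30 log units; within the scatter) from compound 1 to compound 2 and a 1.6-fold higher number (0.20 log units; within the scatter) from compound 3 to compound 4, 3.2-fold (0.51 log units) apart, beyond the scatter of two such steps. The change therefore does not carry over as one fixed step between these two cores, although two pairs cannot show why the steps differ or predict the step on any further core.

On these data alone, it remains open how a methyl ester or an N-methyl amide would behave at this carbonyl carbon. As far as these compounds go, whether a longer chain would alter the step also remains open.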